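Replacing phenoxy with 2,3-dihydro-1H-indol-1-yl in compound 2

A few compounds are considered here, and "the series" means these few. Any claim that something is new, unique, unknown or untested is made for them only; others in the source may bear on it.

Compound 2 `Nc1ccccc1NC(=O)/C=C/c1ccc(COc2ccccc2)cc1` stands at a limit in a functional assay on A549 cells (Homo sapiens) for antiproliferative activity, read by CCK-8 assay, with a stated time of 72 h (a lower number here means a stronger inhibitor, a higher number a weaker inhibitor), with > 32000 nM, so no number is available for it. Compound 3 `Nc1cnccc1NC(=O)/C=C/c1ccc(COc2ccccc2)cc1` also gives only a limit, > 32000 nM. As the limit of > 32000 nM in this assay, at which 2 of the 3 values shown sit, shows, the two limits coincide. Among the measured compounds shown here, the one measured step, a step that the two limits leave unreadable from compound 2 to compound 3, therefore gives no size to carry forward.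

Compound 4 `Nc1ccccc1NC(=O)/C=C/c1ccc(CN2CCc3ccccc32)cc1` follows from compound 2 by a change on a saturated chain carbon bound to an aromatic carbon: 2,3-dihydro-1H-indol-1-yl in place of phenoxy on a saturated chain carbon bound to an aromatic carbon. Compound 1 `O=C(/C=C/c1ccc(CN2CCc3ccccc32)cc1)NO` carries the same 2,3-dihydro-1H-indol-1-yl group on a different amide-type end and gives a measured 5480 nM in this assay. For the measured compounds named here, that value is the only sign of measurable activity with this group, but no measured step isolates the change. Only a modest shift towards stronger inhibition is expected, and compound 4 may well remain at the limit. The expected step is an at least 1.4-fold lower number from compound 2 to compound 4 (0.16 log units; that floor lies within the scatter). Compound 4 is estimated at 22000 nM, with an expected range of 8000 nM to 60000 nM.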

Compound 4, half-maximal inhibitory concentration: 13400 nM
Compound 4: the middle estimate sits 1.6-fold (0.22 log units) above what was measured; measured number inside the range.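

Placed on the saturated chain carbon bound to an aromatic carbon, 2,3-dihydro-1H-indol-1-yl instead of phenoxy gives the 2-aminophenyl amide a readable number in this assay, with an at least 2.3-fold lower number from compound 2 to compound 4 (0.37 log units; beyond the scatter). Compound 2 gives only a limit, > 32000 nM, so the size of this step is a floor, and the same limit recurs in the series: the limit of > 32000 nM in this assay, at which 2 of the 4 values shown sit.

With 2,3-dihydro-1H-indol-1-yl held constant, the amide-type end can now be compared directly, and 2-aminophenyl in place of hydroxy gives a 2.4-fold higher number from compound 1 to compound 4 (0.39 log units; beyond the scatter).

As far as these compounds go, it remains open whether 3-aminopyridin-4-yl on the amide-type nitrogen would keep a readable number alongside 2,3-dihydro-1H-indol-1-yl. A piperidin-1-yl or morpholin-4-yl group on the same saturated chain carbon would test whether the fused aromatic ring of the 2,3-dihydro-1H-indol-1-yl group is needed.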